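From 4-fluorobenzyl to 2,6-difluorobenzyl in a small series

This account rests on a few compounds, and the source may have more. Where it says the series, first, only, none or still open, it means among the compounds named here.

Of the compounds shown here, three have so far been measured in a functional assay on BGC-823 cells (Homo sapiens) for antiproliferative activity, read by MTT assay, with a stated time of 48 h; a higher number here means a weaker inhibitor, a lower number a stronger inhibitor. In this test, compound 1 (`Clc1ccccc1CSc1nnc(-c2cnccn2)s1`) gives 20300 nM, compound 2 (`Clc1cccc(CSc2nnc(-c3cnccn3)n2-c2ccccc2)c1`) gives 20300 nM and compound 3 (`Fc1ccc(CSc2nnc(-c3cnccn3)n2-c2ccccc2)cc1`) gives 27200 nM. Compound 3 therefore lies within the scatter of both other compounds, and the three numbers cannot be ranked. Compound 4 (`Fc1cccc(F)c1CSc1nnc(-c2cnccn2)n1-c1ccccc1`) has not yet been measured. Its difference from compound 3 is 2,6-difluorophenyl in place of 4-fluorophenyl on a saturated chain carbon bound to a sulfur, which puts 2,6-difluorophenyl in place of 4-fluorophenyl on a saturated chain carbon bound to a sulfur. Among the measured compounds shown here, one measured step bears on this change: a 1.3-fold higher number from compound 2 to compound 3 (0.13 log units; within the scatter), a swap at the same place that stayed within the scatter. For the measured compounds named here, that single step is thin evidence, and no measured compound yet carries the 2,6-difluorophenyl group. No step beyond the scatter is therefore expected in this assay. The expected step is a 1.1-fold lower number from compound 3 to compound 4 (0.05 log units; within the scatter). For compound 4, the estimated value is 24000 nM, with an expected range from 11000 nM to 55000 nM.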

Compound 4, half-maximal inhibitory concentration: > 50000 nM
Compound 4 ended at the assay's limit; the forecaster's own chance of this, stated with the estimate: 10%; at least 2.0-fold (0.31 log units) between middle value and limit.
By their numbers in this assay, from the lowest: compounds 1, 2 and 3 (each within the scatter of the next). At a limit, above all of these: compound 4.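

The reading for compound 4 in this assay is a limit of the assay and not a number: the limit of > 50000 nM in this assay, at which 1 of the 4 values shown sits. Among the compounds shown here, the change to 2,6-difluorophenyl gives an at least 2.4-fold higher number from compound 2 to compound 4 (0.39 log units; beyond the scatter) and is the first step on a saturated chain carbon bound to a sulfur to pass beyond the scatter, whereas the swap from 3-chlorophenyl to 4-fluorophenyl stayed within it. The other step, an at least 1.8-fold higher number from compound 3 to compound 4 (0.26 log units; that floor lies within the scatter), has a floor within the scatter, so this pair fixes only a lower bound and leaves the full size of the change unknown.

From the compounds shown here alone, whether the drop in activity is particular to 2,6-difluorophenyl or extends to other groups at this place stays open. The compounds shown also say nothing about a methoxy group, an amine or a carboxylic acid on this ring.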